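The compounds below may be only part of what the source reports. "The series", "measured", "known", "first", "only" and "open" are said of these compounds alone.

Measured so far:
compound 1, `Cc1nc(N)sc1CCCN/C(N)=N/C(=O)NCC(C)CCc1ccccc1`, gives 29.5 nM in a functional assay on membranes from Sf9 cells for agonist activity at histamine H2 receptor (Homo sapiens), read by scintillation counting and GTPgammaS binding, with a stated time of 90 min; on this read-out higher numbers stand for an effect only at larger amounts of compound and lower numbers for an effect already at smaller amounts;
compound 2, `Cc1nc(N)sc1CCCN/C(N)=N/C(=O)NCC(C)CC1CCCCC1`, gives 17.4 nM in this assay.

Compound 2 holds the lower of the two numbers, but its gap to compound 1 lies within the scatter, so the two compounds cannot be ranked against each other. Compound 3, `Cc1ccc(CC(C)CNC(=O)/N=C(\N)NCCCc2sc(N)nc2C)cc1`, differs from compound 2 by 4-methylphenyl in place of cyclohexyl on a saturated chain carbon, three bonds along the chain from an amide-type nitrogen. Within the data shown here, only one measured step touches this place: a 1.7-fold lower number from compound 1 to compound 2 (0.23 log units; within the scatter), an exchange of an aromatic ring for a saturated one at the same chain carbon that did not move the number beyond the scatter. The return to an aromatic ring, now carrying a methyl, is therefore expected to give a step of a 1.4-fold higher number from compound 2 to compound 3 (0.14 log units; within the scatter), again within the scatter. For compound 3 the estimate in this assay is 24 nM, with a range from 8 nM to 70 nM.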

Compound 3, half-maximal effective concentration: 60.3 nM
Compound 3: the middle estimate sits 2.5-fold (0.40 log units) below what was measured; measured number inside the range.
By their numbers in this assay, from the lowest: compounds 2 and 1 (each within the scatter of the next); then compound 3.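

In this assay this position now gives its first steps beyond the scatter: 4-methylphenyl in place of cyclohexyl gives a 3.5-fold higher number from compound 2 to compound 3 (0.54 log units; beyond the scatter), and 4-methylphenyl in place of benzyl gives a 2.0-fold higher number from compound 1 to compound 3 (0.31 log units; beyond the scatter). The chain carbon is therefore not indifferent to the group it carries, although both steps are modest and compound 3 stands apart from two compounds that cannot be ranked against each other. Nothing available gives a reason for these steps.

The compounds shown leave open whether the higher number of compound 3 goes with the methyl or with the aromatic ring that carries it. They also leave open how a 4-fluorophenyl, a 4-aminophenyl or a cyclopentyl would stand at this place.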